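The source may report more compounds than this note shows. Statements on the series, on what has been measured and on what is new or still open speak of the compounds shown alone.

Measured in a functional assay on LS174T cells (Homo sapiens) for antiproliferative activity; a lower number here means a stronger inhibitor, a higher number a weaker inhibitor:

Compound 1, `CN(C)c1ccc(/C=C/c2c(F)cccc2Cl)nc1`: 20.4 nM
Compound 2, `CN(C)c1ccc(/C=C/c2c(Cl)cccc2Cl)nc1`: 59.5 nM
Compound 3, `CN(C)c1ccc(/C=C/c2c(F)cccc2Cl)cn1`: 4.7 nM

Compound 1 and compound 2 share one core and differ in a single place: chloro in place of fluoro on an aromatic carbon. That exchange made a 2.9-fold higher number from compound 1 to compound 2 (0.46 log units; beyond the scatter), so the compound with chloro in that place was the weaker inhibitor of the pair, by a modest margin that still lies beyond the usual scatter.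

Compound 3 is built from the same atoms as compound 1, joined differently; the difference between the two cores is not broken down here. Whatever that rearrangement does, compound 3 at 4.7 nM sits well below compound 1 at 20.4 nM and further still below compound 2 at 59.5 nM, and both gaps exceed the scatter, so compound 3 is the strongest inhibitor of the three in this assay.

Compound 4, `CN(C)c1ccc(/C=C/c2c(Cl)cccc2Cl)cn1`, has not yet been measured. It stands to compound 3 as compound 2 stands to compound 1: chloro in place of fluoro on an aromatic carbon, in a place described in exactly the same words, so this is the same change seen once before.

For the measured compounds named here, the one earlier example of this change gave a 2.9-fold higher number from compound 1 to compound 2 (0.46 log units; beyond the scatter). On that single example rests the expectation that compound 4 will show a step of about a 2.9-fold higher number from compound 3 to compound 4 (0.46 log units; beyond the scatter), landing near 13.5 nM, most likely between 6 nM and 30 nM.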

Compound 4, half-maximal inhibitory concentration: 30.1 nM
Beside the measured number, compound 4's estimate is 2.2-fold (0.35 log units) below it; the whole stated range lies below it.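

In this assay, chloro in place of fluoro on an aromatic carbon gave a 6.4-fold higher number from compound 3 to compound 4 (0.81 log units; beyond the scatter), so the compound with chloro was again the weaker inhibitor of its pair, and the two steps can be set side by side: the same change on two cores in this assay, a 2.9-fold higher number (0.46 log units; beyond the scatter) from compound 1 to compound 2 and a 6.4-fold higher number (0.81 log units; beyond the scatter) from compound 3 to compound 4, 2.2-fold (0.34 log units) apart, within the scatter of two such steps

The change therefore carried over from one core to the other in this series, in direction and, as far as these numbers can tell, in size, so the larger-looking second step should not be read as a true difference between the cores. For the compounds shown here, this rests on only two pairs, however, and it shows neither why chloro gives the weaker inhibitor nor whether the same step would hold on any core beyond these two.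

Going by these compounds, all four compounds carry either fluoro or chloro in this place, so it remains open how a bromo group, a methyl group or a plain hydrogen there would compare. The amine is also the same throughout, which leaves open whether the step would keep its direction and size with an amine carrying longer chains or with a carboxylic acid in its place.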